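Working notes on a three-compound series and one prediction

The compounds below may be only part of what the source reports. "The series", "measured", "known", "first", "only" and "open" are said of these compounds alone.

Measured so far:
Compound 1, `CC(Oc1ccc(Oc2ccc(C(F)(F)F)cc2)cc1)C(=O)Cn1nnc(-c2ccccc2)n1`, in an assay on microsomes from brain for inhibition of Fatty-acid amide hydrolase 1 (Rattus norvegicus), read by fluorescence and HPLC, with a stated time of 60 min (a higher number here means a weaker inhibitor, a lower number a stronger inhibitor), gives 160 nM.
Compound 2, `COC(=O)c1ccc(-c2nnn(CC(=O)C(C)Oc3ccc(Oc4ccc(F)cc4)cc3)n2)cc1`, in this assay gives 36 nM.
Compound 3, `COC(=O)c1ccc(-c2nnn(CC(=O)C(C)Oc3ccc(Oc4ccc(Cl)cc4)cc3)n2)cc1`, in this assay gives 47 nM.

Compound 3 stands second highest of the three numbers in this assay. Its nearest neighbour is compound 2: the step of a 1.3-fold higher number from compound 2 to compound 3 (0.12 log units; within the scatter) lies within the scatter. Among the measured compounds shown here, compound 1 stands furthest away, with a number beyond the scatter from that of compound 3, but compound 1 differs from compound 3 in more than one place, so no single step connects them.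

Compound 4, `COC(=O)c1ccc(-c2nnn(CC(=O)C(C)Oc3ccc(Oc4ccc(C(F)(F)F)cc4)cc3)n2)cc1`, is not yet measured. It differs from compound 3 by trifluoromethyl in place of chloro on an aromatic carbon. For the measured compounds named here, the only measured step touching this position is the halogen swap from compound 2 to compound 3, which stayed within the scatter. Going by the values given here, no measured step isolates a trifluoromethyl against a chloro. The expectation for compound 4 in this assay is therefore a step of a 1.3-fold higher number from compound 3 to compound 4 (0.11 log units; within the scatter) of no clear size beyond the scatter, with a slightly higher number allowed. Compound 4 is estimated at 60 nM, within 25 nM to 140 nM.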

Compound 4, half-maximal inhibitory concentration: 130 nM
Estimate against measurement, compound 4: 2.2-fold (0.34 log units) below; the measured number falls inside the stated range.
By their numbers in this assay, from the lowest: compounds 2 and 3 (each within the scatter of the next); then compounds 4 and 1 (each within the scatter of the next).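

In this assay, among the compounds shown here, this position on the terminal aromatic ring is the first to show a readable change: trifluoromethyl in place of chloro gives a 2.8-fold higher number from compound 3 to compound 4 (0.44 log units; beyond the scatter), and trifluoromethyl in place of fluoro gives a 3.6-fold higher number from compound 2 to compound 4 (0.56 log units; beyond the scatter), while the swap between the two halogens gave only a 1.3-fold higher number from compound 2 to compound 3 (0.12 log units; within the scatter). With trifluoromethyl held in place, methoxycarbonyl in place of hydrogen on the other aromatic ring gives a 1.2-fold lower number from compound 1 to compound 4 (0.09 log units; within the scatter), so that change has no readable effect in this pair. Nothing measured here accounts for the trifluoromethyl step.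

The compounds shown leave open where a methyl or methoxy group at this position would fall relative to the halogens and trifluoromethyl. They also leave open whether a carboxylic acid in place of methoxycarbonyl would change the number with either halogen present.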